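The source may report more compounds than this note shows. Statements on the series, on what has been measured and on what is new or still open speak of the compounds shown alone.

Compound 1 `COc1cccc(Cc2cnc(CCc3ccc(-c4ccccc4C(=O)O)cc3)[nH]2)c1` gives 4120 nM in an in vitro functional assay on cells for agonist activity at Bombesin receptor subtype-3 (Homo sapiens), read by luminescence and calcium flux; a higher number here means that more compound is needed for the effect, a lower number that less compound is needed.
Compound 2 `O=C(O)c1ccccc1-c1ccc(CCc2ncc(CCc3ccccc3)[nH]2)cc1` gives 1320 nM in this assay.
Compound 3 `CC(C)(C)CCc1cnc(CCc2ccc(-c3ccccc3C(=O)O)cc2)[nH]1` gives 39 nM in this assay.

Compound 3 stands lowest of the three numbers, and both gaps to it are beyond the scatter: a 34-fold lower number from compound 2 to compound 3 (1.53 log units; beyond the scatter) and a 110-fold lower number from compound 1 to compound 3 (2.02 log units; beyond the scatter). Between the other two the step is smaller, a 3.1-fold lower number from compound 1 to compound 2 (0.49 log units; beyond the scatter).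

Compound 4 `CCC(C)(CC)Cc1cnc(CCc2ccc(-c3ccccc3C(=O)O)cc2)[nH]1` differs from compound 3 in one place: 1-ethyl-1-methylpropyl in place of neopentyl on a saturated chain carbon bound to an aromatic carbon. The two large steps measured so far, from compound 1 and from compound 2 to compound 3, each replaced an aromatic group with a branched saturated chain on the same carbon, and both gave a large drop. Among the compounds with values here, the step to compound 4 is of a different kind: one branched saturated chain is exchanged for a closely related one, and no measured pair tests a change this small within saturated groups. Nothing in the data points in either direction, so the expected step in this assay is small, within the scatter or at most modest. Compound 4 is therefore expected to give about 40 nM, in the range 15 nM to 120 nM. This means an expected step of a 1.0-fold higher number from compound 3 to compound 4 (0.01 log units; within the scatter).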

Compound 4, half-maximal effective concentration: 76 nM
Compound 4: the middle estimate sits 1.9-fold (0.28 log units) below what was measured; the measured number falls inside the stated range.
By their numbers in this assay, from the lowest: compounds 3 and 4 (each within the scatter of the next); then compound 2; then compound 1.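

In this assay, swapping neopentyl (5 heavy atoms) for 1-ethyl-1-methylpropyl (6 heavy atoms) on this saturated chain carbon gives a step within the scatter (a 1.9-fold higher number from compound 3 to compound 4 (0.29 log units; within the scatter)), so the two branched saturated groups cannot be told apart here, and this position accepts one extra carbon in the branched group with no measurable loss. The large advantage over the compounds whose groups carry a ring also holds for this second branched group (a 17-fold lower number from compound 2 to compound 4 (1.24 log units; beyond the scatter); a 54-fold lower number from compound 1 to compound 4 (1.73 log units; beyond the scatter)), which shows that the low number of compound 3 does not depend on neopentyl alone, and no listed compound goes against this within the four shown. No measured evidence on hand explains why these two groups behave alike or why both differ so much from benzyl and 3-methoxyphenyl.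

The compounds shown leave open whether a saturated ring such as cyclohexyl, or an unbranched chain such as n-hexyl, would also keep the number this low. They also leave open whether a hydroxyl group or an amine placed on the branched chain would be accepted at this position.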